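Trifluoromethyl in Place of a Larger Fluorinated Group

A few compounds are considered here, and "the series" means these few. Any claim that something is new, unique, unknown or untested is made for them only; others in the source may bear on it.

In a functional assay on LNCaP cells (Homo sapiens) for antiproliferative activity, read by fluorescence and propidium iodide staining, with a stated time of 96 h (a lower number here means a stronger inhibitor, a higher number a weaker inhibitor), the measured compounds are:
compound 1 `O=C(Nc1ccc(S(F)(F)(F)(F)F)cc1)c1ccc(Sc2ccc(O)cc2)cc1` gives 4860 nM
compound 2 `O=C(Nc1ccc(C(F)(F)F)cc1)c1ccc(Sc2ccc(O)cc2)cc1` gives 8300 nM
compound 3 `O=C(Nc1cccc(S(F)(F)(F)(F)F)c1)c1ccc(S(=O)(=O)c2ccc(O)cc2)cc1` gives 3980 nM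

Compound 2 differs from compound 1 by a group of 4 heavy atoms (1 carbon, 3 fluorine; no ring) in place of a group of 6 heavy atoms (5 fluorine, 1 sulfur; no ring), on an aromatic carbon, and that change made a 1.7-fold higher number from compound 1 to compound 2 (0.23 log units; within the scatter). Compound 4 `O=C(Nc1cccc(C(F)(F)F)c1)c1ccc(S(=O)(=O)c2ccc(O)cc2)cc1` has not yet been measured in this assay. It differs from compound 3 by a group of 4 heavy atoms (1 carbon, 3 fluorine; no ring) in place of a group of 6 heavy atoms (5 fluorine, 1 sulfur; no ring), on an aromatic carbon, the same kind of change as before, though the group now sits meta to a large group rather than para to it. The difference between the cores of compound 1 and compound 3 is not broken down here. Compound 4 is expected to give about 6000 nM in this assay, estimated between 3000 nM and 12000 nM. The expected step is a 1.5-fold higher number from compound 3 to compound 4 (0.18 log units; within the scatter), because the earlier change gave a 1.7-fold higher number from compound 1 to compound 2 (0.23 log units; within the scatter).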

Compound 4, half-maximal inhibitory concentration: 10200 nM
The estimate for compound 4 lay 1.7-fold (0.23 log units) below the measured number; the range from low to high includes it.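

Trifluoromethyl in place of the larger fluorinated group in this assay gave a 2.6-fold higher number from compound 3 to compound 4 (0.41 log units; beyond the scatter) on the core of compound 3, and the earlier step on the core of compound 1 ran the same way. Set side by side, the two steps do not differ beyond what repeated measurement allows: the same change on two cores in this assay, a 1.7-fold higher number (0.23 log units; within the scatter) from compound 1 to compound 2 and a 2.6-fold higher number (0.41 log units; beyond the scatter) from compound 3 to compound 4, 1.5-fold (0.18 log units) apart, within the scatter of two such steps.
This shows that the change carried over in direction on these two cores, but two pairs do not fix a size that would hold across the series, nor do they separate the effect of the core from that of where the group sits. The compounds shown leave open whether a nitrile, an amine or a carboxylic acid in that place would follow the same course.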